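The source may report more compounds than this note shows. Statements on the series, on what has been measured and on what is new or still open speak of the compounds shown alone.

Compound 1 `O=S(=O)(NCCNCc1cccc2ccccc12)c1cc(C(F)(F)F)cc(C(F)(F)F)c1` gives 26000 nM in a functional assay on MIA PaCa-2 cells (Homo sapiens) for inhibition, read by MTT assay, with a stated time of 72 h; on this read-out higher numbers stand for weaker inhibition of growth and lower numbers for stronger inhibition of growth.
Compound 2 `O=S(=O)(NCCNCc1ccc(-c2ccccc2)cc1)c1cc(C(F)(F)F)cc(C(F)(F)F)c1` gives 2700 nM in this assay.
Compound 3 `O=S(=O)(NCCCCNCc1ccc(Br)cc1)c1cc(C(F)(F)F)cc(C(F)(F)F)c1` gives 2100 nM in this assay.

Of these three, compound 3 has the lowest number. Compound 2 lies within the usual scatter of compound 3, so the two cannot be separated on these data. Compound 1 lies well beyond the scatter from compound 3, the one gap among the three that counts as real.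

Compound 4 `O=S(=O)(NCCCNCc1cccc(Cl)c1)c1cc(C(F)(F)F)cc(C(F)(F)F)c1` has not yet been measured in this assay. It differs from compound 3 in a single place: (3-chlorobenzyl)amino in place of ((4-bromobenzyl)amino)methyl on a saturated chain carbon, three bonds along the chain from a sulfonamide nitrogen. Going by the values given here, no pair of measured compounds differs by this change alone, so there is no step to lean on directly. On these data alone, what the three measured compounds do show is that varying the ring-bearing end and the chain moves the number from the region of compound 3 up to that of compound 1, and that a different benzyl substitution pattern with a shortened chain is untested here.

Compound 4 is therefore expected to stay close to compound 3, with a modest rise in the number that could still fall within the scatter, a step of a 1.9-fold higher number from compound 3 to compound 4 (0.28 log units; within the scatter). For compound 4 the estimate is 4000 nM, with a range from 1500 nM to 12000 nM.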

Compound 4, concentration for 50% growth inhibition: 4400 nM
Compound 4: the middle estimate sits 1.1-fold (0.04 log units) below what was measured, and the stated range covers the measured number.
By their numbers in this assay, from the lowest: compounds 3, 2 and 4 (each within the scatter of the next, the first and the last beyond it); then compound 1.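

Going by these compounds alone, the swap of ((4-bromobenzyl)amino)methyl for (3-chlorobenzyl)amino, on a saturated chain carbon three bonds along the chain from a sulfonamide nitrogen, gives the first step that can be read in this assay: a 2.1-fold higher number from compound 3 to compound 4 (0.32 log units; beyond the scatter). The step is modest, so at this position the change from the 4-bromobenzyl group on the longer chain to the 3-chlorobenzyl group on the shorter one costs some growth inhibition but leaves compound 4 far closer to compound 3 than the gap the earlier numbers showed between compound 3 and compound 1. No measurement bearing on the origin of this step is available.

The single swap changes the halogen, its place on the ring and the chain length together, and the compounds shown include no pair that changes just one of these, so the share of each in the step stays open. Also open, on these data alone, is how the number would respond to an unsubstituted benzyl group or a fluorine on the benzyl ring at this end of the molecule, or to a longer chain carrying the 3-chlorobenzyl group.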